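The source may hold more compounds than are shown below. What is called first, only, known or untested is meant among the compounds shown, and "the series" means these compounds.

Measured in an ADME assay on RAW264.7 cells (Mus musculus) for cytotoxicity, read by MTT assay, with a stated time of 24 h; on this read-out lower numbers stand for higher toxicity in this test and higher numbers for lower toxicity in this test:
- compound 1 `CC/C=C\C[C@H]1C(=O)C=C[C@H]1CC(=O)OCCCC`: 31 uM
- compound 2 `CC/C=C\C[C@H]1C(=O)C=C[C@H]1CC(=O)OC(C)(C)C`: 33 uM

Compound 2, at 33 uM, stands level with compound 1 within the scatter, so neither compound can be ranked above the other. The next structure, compound 3 `CC/C=C\C[C@H]1C(=O)C=C[C@H]1CC(=O)OC(C)COC`, carries 1-(methoxymethyl)ethyl in place of tert-butyl on an oxygen next to a carbonyl group. Among the compounds with values here, only one measured step bears on this place: a 1.1-fold higher number from compound 1 to compound 2 (0.03 log units; within the scatter). That step, with tert-butyl in place of butyl, stayed within the scatter. It is thin evidence, since neither measured group contains the oxygen that enters here. No step beyond the scatter is therefore expected in this assay. The expected result is a 1.1-fold higher number from compound 2 to compound 3 (0.03 log units; within the scatter). For compound 3 the estimated value is 35 uM, with an expected range of 16 uM to 75 uM.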

Compound 3, half-maximal toxic concentration: 161 uM
Beside the measured number, compound 3's estimate is 4.6-fold (0.66 log units) below it; measured number outside the range, above it.
By their numbers in this assay, from the lowest: compounds 1 and 2 (each within the scatter of the next); then compound 3.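

In this assay this position, on an oxygen next to a carbonyl group, proves responsive: the swap of butyl for tert-butyl stayed within the scatter, but 1-(methoxymethyl)ethyl gives a 4.9-fold higher number from compound 2 to compound 3 (0.69 log units; beyond the scatter) and a 5.2-fold higher number from compound 1 to compound 3 (0.72 log units; beyond the scatter). Both steps are modest, lie beyond the scatter and run towards lower toxicity in this test. Of the three groups, only 1-(methoxymethyl)ethyl counts a hydrogen-bond acceptor, yet nothing available explains the shift.

Open, going by these compounds, is whether the oxygen or the branched chain carries the step, which a straight 2-methoxyethyl group or a longer chain with the same ether oxygen could separate. Also open, on these data alone, is whether a hydroxyl group, an amine or a carboxylic acid at this position would move the number further in the same direction or reverse it.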